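This account rests on a few compounds, and the source may have more. Where it says the series, first, only, none or still open, it means among the compounds named here.

In a functional assay on SK-MEL-5 cells (Homo sapiens) for inhibition (a lower number here means a stronger inhibitor of growth, a higher number a weaker inhibitor of growth), compound 3 `COc1ccc(-c2cn(-c3cccc(C(=O)/C=C/c4ccc(O)c(OC)c4)c3)c(=O)[nH]2)cc1` gives 2630 nM, the second highest of the three numbers measured. Compound 1 `COc1cc(/C=C/C(=O)c2cccc(-n3cc(-c4ccc(Cl)cc4)[nH]c3=O)c2)cc(OC)c1OC` gives 8700 nM, and compound 2 `COc1cc(/C=C/C(=O)c2cccc(-n3cc(-c4ccccc4)[nH]c3=O)c2)cc(OC)c1OC` gives 1400 nM; compound 3 thus lies within the scatter of compound 2 and differs beyond it only from compound 1. Among the measured compounds shown here, the single measured step, a 6.2-fold lower number from compound 1 to compound 2 (0.79 log units; beyond the scatter), concerns chloro against hydrogen on an aromatic carbon and does not bear on the change now considered. Compound 4 `COc1ccc(-c2cn(-c3cccc(C(=O)/C=C/c4cc(OC)c(OC)c(OC)c4)c3)c(=O)[nH]2)cc1` carries 3,4,5-trimethoxyphenyl in place of 4-hydroxy-3-methoxyphenyl on a double-bonded chain carbon bound to a double-bonded chain carbon. Compounds 1 and 2 already carry the entering ring, and compound 2 sits close to compound 3. No step beyond the scatter is therefore expected. Compound 4 is estimated at 1800 nM, within 600 nM to 6000 nM. The expected step is a 1.5-fold lower number from compound 3 to compound 4 (0.16 log units; within the scatter).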

Compound 4, concentration for 50% growth inhibition: 2030 nM
For compound 4 the middle estimate is 1.1-fold (0.05 log units) below the measured one, and the stated range covers the measured number.
By their numbers in this assay, from the lowest: compounds 2, 4 and 3 (each within the scatter of the next); then compound 1.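

In this assay, 3,4,5-trimethoxyphenyl in place of 4-hydroxy-3-methoxyphenyl on a double-bonded chain carbon bound to a double-bonded chain carbon gives a 1.3-fold lower number from compound 3 to compound 4 (0.11 log units; within the scatter) and so no change beyond the scatter, even though the one hydrogen-bond donor of the leaving group is gone. At the other aromatic carbon, methoxy in place of hydrogen gives a 1.5-fold higher number from compound 2 to compound 4 (0.16 log units; within the scatter) within the scatter as well, whereas methoxy in place of chloro gives a 4.3-fold lower number from compound 1 to compound 4 (0.63 log units; beyond the scatter) beyond it. As far as these compounds go, whether a phenyl ring carrying an amine or a carboxylic acid would fit this position equally well remains open. Nothing at hand speaks to what lies behind these steps.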